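Compound 1 and its propanoyl counterpart, compound 4

The compounds below may be only part of what the source reports. "The series", "measured", "known", "first", "only" and "open" are said of these compounds alone.

Measured so far in an ADME assay on HepG2 2.2.15 cells (Homo sapiens) for cytotoxicity; a higher number here means that more compound is tolerated, a lower number that less compound is tolerated:
- compound 1 `O=c1[nH]c2ccc(Cl)cc2c(-c2ccccc2Cl)c1CCO` gives 380000 nM
- compound 2 `Cn1c(=O)c(CCO)c(-c2ccccc2Cl)c2cc(Cl)ccc21` gives 34000 nM
- compound 3 `O=c1c(CCO)c(-c2ccccc2Cl)c2cc(Cl)ccc2n1-c1ccccc1` gives 26000 nM

Compound 1 stands highest of the three, and the other two lie beyond the scatter below it. Compound 4 `CCC(=O)OCCc1c(-c2ccccc2Cl)c2cc(Cl)ccc2[nH]c1=O` is still unmeasured. It carries propanoyl in place of hydrogen on an oxygen on a saturated carbon, so that 2-hydroxyethyl becomes 2-(propanoyloxy)ethyl, and the difference reads propanoyl in place of hydrogen on an oxygen on a saturated carbon in full.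

For the measured compounds named here, no measured step touches that oxygen. The nearest evidence comes from substitution on an aromatic nitrogen, where the data show an 11-fold lower number from compound 1 to compound 2 (1.05 log units; beyond the scatter) and also a 15-fold lower number from compound 1 to compound 3 (1.16 log units; beyond the scatter), both large. Methyl and phenyl hardly separate there, with a 1.3-fold lower number from compound 2 to compound 3 (0.12 log units; within the scatter) inside the scatter. Both steps replace a hydrogen of compound 1 and both lower the number, but they sit at another place in the molecule and so bear on this change only loosely.

A lower number is therefore expected, though a smaller drop than those two, and the range stays wide. The expected change is a 3.2-fold lower number from compound 1 to compound 4 (0.50 log units; beyond the scatter) in this assay by this estimate. For compound 4 the estimated value is 120000 nM, with the expected range running from 30000 nM to 400000 nM in this reading.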

Compound 4, half-maximal cytotoxic concentration: 95000 nM
For compound 4 the middle estimate is 1.3-fold (0.10 log units) above the measured one; the measured number falls inside the stated range.
By their numbers in this assay, from the lowest: compounds 3 and 2 (each within the scatter of the next); then compound 4; then compound 1.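

In this assay, the oxygen of the 2-hydroxyethyl chain proves to be a position that responds to substitution: propanoyl in place of hydrogen on this oxygen gives a 4.0-fold lower number from compound 1 to compound 4 (0.60 log units; beyond the scatter). For the compounds shown here, this is the first measured change at that oxygen, and the step counts as modest, whereas the two earlier replacements of a hydrogen of compound 1, made on the aromatic nitrogen, count as large, with an 11-fold lower number from compound 1 to compound 2 (1.05 log units; beyond the scatter) and a 15-fold lower number from compound 1 to compound 3 (1.16 log units; beyond the scatter). So a hydrogen of compound 1 has now been replaced at two separate places, and the number falls beyond the scatter at both, but no supporting measurement accounts for the fall at this oxygen.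

With propanoyl as the only group shown on this oxygen, it remains open whether a shorter acetyl group, a longer butanoyl chain, a methyl ether or a carbamate would give a step of similar size. It is also open how propanoyl on this oxygen would behave together with methyl or phenyl on the aromatic nitrogen, since the compounds shown carry only one of these changes at a time.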